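Swapping an imidazole for a pyridine on the core

The source may hold more compounds than are shown below. What is called first, only, known or untested is meant among the compounds shown, and "the series" means these compounds.

Three compounds have been characterised in an assay with Thromboxane-A synthase (Homo sapiens) as the target, using microsomes; a higher number here means a weaker inhibitor, a lower number a stronger inhibitor. Compound 1 `Cc1c(Cn2ccnc2)n(CCCNS(=O)(=O)c2ccc(F)cc2)c2ccc(C(=O)O)cc12` gives 15 nM, compound 2 `Cc1[nH]c2ccc(CCC(=O)O)cc2c1Cc1ccncc1` gives 22 nM, and compound 3 `Cc1c(Cn2ccnc2)c2cc(CCC(=O)O)ccc2n1CCNS(=O)(=O)c1ccc(F)cc1` gives 39 nM. Among these, compound 3 carries the largest number: its gap to compound 1 lies beyond the usual scatter of this assay, whereas its gap to compound 2 lies within that scatter, so compound 2 and compound 3 cannot be told apart on these numbers.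

Compound 4 `Cc1c(Cc2cccnc2)c2cc(CCC(=O)O)ccc2n1CCNS(=O)(=O)c1ccc(F)cc1` is the next compound to be examined. For the measured compounds named here, it is obtained from compound 3 by the single change pyridin-3-yl in place of 1H-imidazol-1-yl on a saturated chain carbon bound to an aromatic carbon. Going by the values given here, no direct pair of measured compounds isolates this change, so its size has to be estimated rather than read off.

For this assay the change is expected to lower the number somewhat, by a step of about a 1.6-fold lower number from compound 3 to compound 4 (0.19 log units; within the scatter), though a result within the scatter would not be surprising. On that basis compound 4 is estimated to give 25 nM in this assay, with a likely range from 8 nM to 80 nM.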

Compound 4, half-maximal inhibitory concentration: 61 nM
The estimate for compound 4 lay 2.4-fold (0.39 log units) below the measured number, within the range that was stated.
By their numbers in this assay, from the lowest: compounds 1, 2, 3 and 4 (each within the scatter of the next, the first and the last beyond it).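

In this assay, for the compounds shown here, putting pyridin-3-yl in place of 1H-imidazol-1-yl on a saturated chain carbon bound to an aromatic carbon gives a 1.6-fold higher number from compound 3 to compound 4 (0.19 log units; within the scatter), and this is the first step that isolates a single change. At this place, therefore, a six-membered aromatic ring with 1 hetero atom and a five-membered aromatic ring with 2 hetero atoms cannot be told apart on these numbers, so on this scaffold the 1H-imidazol-1-yl group is not needed to keep the number in the range of compound 3. Nothing available explains why the two groups read alike in this assay, and no independent measurement bears on the result.

The compounds shown leave open whether any ring on this carbon would serve equally well, for instance a plain phenyl ring, which has no ring nitrogen, or pyridin-2-yl, which places the ring nitrogen differently. They also leave open whether the same swap would give a step of similar size on compound 1, which differs from compound 3 in more than one place.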